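A few compounds are considered here, and "the series" means these few. Any claim that something is new, unique, unknown or untested is made for them only; others in the source may bear on it.

Measured compounds:
- Compound 1 `Nc1nc(-c2ccc(Cl)cc2)c(CC(=O)O)s1`; in an in vitro assay on HEK385-7 cells for displacement of a labelled ligand from prostaglandin D2 receptor 2 (Homo sapiens) (a lower number here means a stronger inhibitor, a higher number a weaker inhibitor), compound 1 gives only a limit, > 100000 nM.
- Compound 2 `O=C(O)Cc1sc(C(c2ccc(F)cc2)c2ccc(F)cc2)nc1-c1cc(F)cc(F)c1`; in this assay compound 2 gives 35 nM.
- Compound 3 `O=C(O)Cc1sc(C2COc3ccccc3O2)nc1-c1ccc(Cl)cc1`; in this assay compound 3 gives 500 nM.

The three share a core carrying a carboxymethyl group, and they differ in the groups attached to it. Of the two numbers given, compound 2 has the lowest, and the gap from compound 2 to compound 3 lies beyond the usual scatter of repeated measurements. The value of compound 1 is a limit of this assay and not a number, as noted at the limit of > 100000 nM in this assay, at which 1 of the 3 values shown sits.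

The next compound, compound 4 `CS(=O)(=O)Nc1cccc(-c2nc(C(c3ccc(F)cc3)c3ccc(F)cc3)sc2CC(=O)O)c1`, keeps the bis(4-fluorophenyl)methyl group and the carboxymethyl group of compound 2 and changes only one aromatic ring:

3-(methanesulfonamido)phenyl in place of 3,5-difluorophenyl on an aromatic carbon

Among the compounds with values here, no pair of measured compounds differs in this one place, so there is no measured step to lean on. The new group is larger and brings a hydrogen-bond donor and acceptors where compound 2 has only fluorine. Given that compound 2 sits at 35 nM, compound 4 is expected to stay in the same region, with a step of a 1.7-fold higher number from compound 2 to compound 4 (0.23 log units; within the scatter) that may fall inside the scatter or amount to a modest loss. The estimate for compound 4 in this assay is 60 nM, within a range from 15 nM to 250 nM.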

Compound 4, half-maximal inhibitory concentration: 40 nM
The estimate for compound 4 lay 1.5-fold (0.18 log units) above the measured number; measured number inside the range.
By their numbers in this assay, from the lowest: compounds 2 and 4 (each within the scatter of the next); then compound 3. At a limit, above all of these: compound 1.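

In this assay the change gives a 1.1-fold higher number from compound 2 to compound 4 (0.06 log units; within the scatter) and so shows that this place, on an aromatic carbon next to the ring nitrogen and next to the ring atom that bears a carboxymethyl group, accepts 3-(methanesulfonamido)phenyl in place of 3,5-difluorophenyl with no difference that can be told from the scatter. Within the data shown here, this is the only measured change at this place, and it shows that a group with more heavy atoms, a hydrogen-bond donor and hydrogen-bond acceptors can stand here, where 3,5-difluorophenyl has no donor or acceptor, as long as the bis(4-fluorophenyl)methyl group and the carboxymethyl group stay as they are. Nothing measured in these compounds gives a reason why the two groups match so closely.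

The compounds shown leave open how much the methanesulfonamido group itself contributes, since a plain phenyl ring, or an amine or a carboxylic acid in its place, would be needed to tell. From the compounds shown here alone, it also remains open whether this place would accept the same change with a different group in place of bis(4-fluorophenyl)methyl.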